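Fluoro-to-methoxy swap on a second indole scaffold

The source may report more compounds than this note shows. Statements on the series, on what has been measured and on what is new or still open speak of the compounds shown alone.

Measured compounds:
compound 1 `CC(=O)c1cc(-c2ccc(F)cc2)cc2cc(-c3ccccc3)[nH]c12`, 90.3%
compound 2 `COc1ccc(-c2cc(C(C)=O)c3[nH]c(-c4ccccc4)cc3c2)cc1`, 87.9%
compound 3 `CC(=O)c1cc(-c2ccc(F)cc2)cc2cc(-c3ccc(F)cc3)[nH]c12`, 90.1%

Of the compounds shown here, three have been tested in a functional assay on HeLa cells (Homo sapiens) for cytotoxicity, read by MTT assay, with a stated time of 2 days, tested at 0.1 uM; a lower number here means a stronger effect, a higher number a weaker effect of the compound at the concentration tested. Compound 1 `CC(=O)c1cc(-c2ccc(F)cc2)cc2cc(-c3ccccc3)[nH]c12` gives 90.3% in this assay. Compound 2 `COc1ccc(-c2cc(C(C)=O)c3[nH]c(-c4ccccc4)cc3c2)cc1` differs from it by methoxy in place of fluoro on an aromatic carbon and gives 87.9%, a step of a number 2.4 percentage points lower from compound 1 to compound 2 (within the scatter). Compound 3 `CC(=O)c1cc(-c2ccc(F)cc2)cc2cc(-c3ccc(F)cc3)[nH]c12` differs from compound 1 by fluoro in place of hydrogen on an aromatic carbon; in this assay compound 3 gives 90.1%, a step of a number 0.2 percentage points lower from compound 1 to compound 3 (within the scatter). All three values sit close together.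

Compound 4 `COc1ccc(-c2cc(C(C)=O)c3[nH]c(-c4ccc(F)cc4)cc3c2)cc1` has not been measured. For the measured compounds named here, it differs from compound 3 by methoxy in place of fluoro on an aromatic carbon, which is the same change as the one from compound 1 to compound 2, made at a place described in the same words on the core of compound 3. Because the earlier step was a number 2.4 percentage points lower from compound 1 to compound 2 (within the scatter), the step from compound 3 to compound 4 is expected to be a number 2.1 percentage points lower from compound 3 to compound 4 (within the scatter). Compound 4 is therefore estimated at 88%, with a range from 78% to 96%.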

Compound 4, a percentage reported as activity, at one concentration (the size of the read-out at that concentration, not a potency): 74.5%
The estimate for compound 4 lay 13.5 percentage points above the measured number; the measured number lies below the stated range.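

In this assay, replacing fluoro with methoxy on the core of compound 3 gives a number 15.6 percentage points lower from compound 3 to compound 4 (beyond the scatter), and adding fluoro in place of hydrogen on the core of compound 2 gives a number 13.4 percentage points lower from compound 2 to compound 4 (beyond the scatter); both steps lie beyond the scatter. The same methoxy change looked negligible on the core of compound 1, yet the two steps cannot be told apart with confidence: the same change on two cores in this assay, a number 2.4 percentage points lower (within the scatter) from compound 1 to compound 2 and a number 15.6 percentage points lower (beyond the scatter) from compound 3 to compound 4, 13.2 percentage points apart, within the scatter of two such steps The fluoro change reads the same way, so these pairs show neither that each change carries over unchanged from one core to the other nor that the core alters it: the same change on two cores in this assay, a number 0.2 percentage points lower (within the scatter) from compound 1 to compound 3 and a number 13.4 percentage points lower (beyond the scatter) from compound 2 to compound 4, 13.2 percentage points apart, within the scatter of two such steps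

The compounds shown leave open how an amine or a carboxylic acid would read in this assay in the place now held by the methoxy, and whether a longer chain there, such as ethoxy, would fall close to compound 4. With one read-out at a single concentration, they also leave open how potent any of these compounds is.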